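Dihydroxy replacement in the triazole-pyridine series

The source may report more compounds than this note shows. Statements on the series, on what has been measured and on what is new or still open speak of the compounds shown alone.

Measured so far, in a functional assay on HCT-116 cells (Homo sapiens) for inhibition, read by MTT assay, with a stated time of 48 h; a lower number here means a stronger inhibitor, a higher number a weaker inhibitor:
Compound 1, `Brc1ccccc1CSc1nnc(-c2ccncc2)n1-c1ccccc1`: 20200 nM
Compound 2, `c1ccc(CSc2nnc(-c3ccncc3)n2-c2ccccc2)cc1`: 16900 nM
Compound 3, `O=C(CSc1nnc(-c2ccncc2)n1-c1ccccc1)N/N=C/c1ccc(O)cc1`: > 50000 nM

The value of compound 3 is a limit of this assay, not a number; it is the one of the three that sits at the limit of > 50000 nM in this assay, at which 1 of the 3 values shown sits. Within the data shown here, compound 1 and compound 2 both give numbers, and the only step measured between neighbours, a 1.2-fold lower number from compound 1 to compound 2 (0.08 log units; within the scatter), does not rise above the scatter.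

Compound 4, `O=C(CSc1nnc(-c2ccncc2)n1-c1ccccc1)N/N=C/c1ccc(O)c(O)c1`, is not yet measured. It differs from compound 3 by hydroxy in place of hydrogen on an aromatic carbon. Among the measured compounds shown here, no measured step touches this part of the molecule: the one step in hand concerns the bromo substituent on the other arm of the series, so it gives no guide to the direction of this change. With compound 3 already at the limit, the expectation is that compound 4 remains at or near it, with the step that the limit leaves unreadable from compound 3 to compound 4 expected to be small. Compound 4 is therefore estimated at 60000 nM, in the range 25000 nM to 200000 nM, most probably reported as a limit again.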

Compound 4, half-maximal inhibitory concentration: 14700 nM
Compound 4: the middle estimate sits 4.1-fold (0.61 log units) above what was measured; the measured number lies below the stated range.
By their numbers in this assay, from the lowest: compounds 4, 2 and 1 (each within the scatter of the next). At a limit, above all of these: compound 3.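

In this assay, among these compounds, hydroxy in place of hydrogen on the aromatic carbon ortho to a hydroxy group gives the first step that lies beyond the scatter (an at least 3.4-fold lower number from compound 3 to compound 4 (0.53 log units; beyond the scatter)). The earlier bromo-to-hydrogen step gave no reading on this arm, whereas the change from 4-hydroxyphenyl to 3,4-dihydroxyphenyl shows that substitution on this ring can bring the series from a limit to a number. Going by these compounds, compound 3 stands at a limit of this assay and not at a number, so the step gives only a bound and its true size stays open: (the limit of > 50000 nM in this assay, at which 1 of the 4 values shown sits).

On these data alone, it remains open whether the effect requires both hydroxy groups or only the added one. As far as these compounds go, it is also open whether a methoxy group, an amine or a carboxylic acid on the same carbon would give a similar step.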